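A few compounds are considered here, and "the series" means these few. Any claim that something is new, unique, unknown or untested is made for them only; others in the source may bear on it.

Measured so far:
compound 1 `COc1ccc(NC(=O)C(=O)c2cn(C(C)C)c3ccc(Cl)cc23)cc1`, > 10000 nM
compound 2 `COCC(C)n1cc(C(=O)C(=O)Nc2ccc(OC)nc2)c2ccccc21`, 12 nM

In a functional assay on FaDu cells (Homo sapiens) for cytotoxicity, read by MTT assay, with a stated time of 72 h (a lower number here means that less compound is tolerated, a higher number that more compound is tolerated), compound 1 gives only a limit, > 10000 nM; this is the limit of > 10000 nM in this assay, at which 1 of the 2 values shown sits. Compound 2 gives 12 nM in this assay and so holds the only number shown. Among the compounds with values here, compounds 1 and 2 differ in several places at once, so no single step joins them. Compound 3 `COc1ccc(NC(=O)C(=O)c2cn(CCOC(C)C)c3ccccc23)cn1` is next, with 2-isopropoxyethyl in place of 1-(methoxymethyl)ethyl on an aromatic nitrogen. Both chains are short alkoxyalkyl groups of similar size, so the step is expected to stay small: a 1.7-fold higher number from compound 2 to compound 3 (0.22 log units; within the scatter), in either direction, within the scatter or barely beyond it. Compound 3 is therefore expected to give 20 nM in this assay, between 5 nM and 80 nM.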

Compound 3, concentration lethal to 50% of the cells: 211 nM
The estimate for compound 3 lay 11-fold (1.02 log units) below the measured number; the whole stated range lies below it.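

The position on the aromatic nitrogen is sensitive: with the shared core unchanged, 2-isopropoxyethyl in place of 1-(methoxymethyl)ethyl gives an 18-fold higher number from compound 2 to compound 3 (1.25 log units; beyond the scatter) in this assay. Both chains are uncharged, lack a ring and match in hydrogen-bond donors and acceptors, so these counts do not separate the two compounds. Nothing measured here accounts for the size of the step.

Open, as far as these compounds go, is whether a longer alkyl chain, or an amine at the end of this chain, would give a value nearer compound 2 or compound 3.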